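The compounds below may be only part of what the source reports. "The series", "measured", "known", "first", "only" and "open" are said of these compounds alone.

Compound 1 `O=c1c(CSC(=S)N2CCCCC2)coc2cc(Cl)ccc12` is the reference point of this set. In a functional assay on HEp-2 cells (Homo sapiens) for antiproliferative activity, read by MTT assay, with a stated time of 72 h (on this read-out lower numbers stand for stronger inhibition and higher numbers for weaker inhibition), compound 1 gives 280 nM, the lowest of the three numbers recorded. Compound 2 `O=c1c(CSC(=S)N2CCOCC2)coc2cc(Cl)ccc12` gives 900 nM in this assay, and compound 3 `CC(C)N(C(=S)SCc1coc2cc(Cl)ccc2c1=O)C(C)C` gives 4200 nM. The measured steps all vary the group on the thiocarbonyl carbon: a 3.2-fold higher number from compound 1 to compound 2 (0.51 log units; beyond the scatter), a 15-fold higher number from compound 1 to compound 3 (1.18 log units; beyond the scatter) and a 4.7-fold higher number from compound 2 to compound 3 (0.67 log units; beyond the scatter).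

Compound 4 `O=c1c(CSC(=S)N2CCCCC2)coc2ccccc12` keeps the piperidin-1-yl of compound 1 and changes the aromatic ring instead: hydrogen in place of chloro on an aromatic carbon. Among the measured compounds shown here, none of the measured steps touches this position, so no step in the set bears directly on the change. The substituent that is removed is small and carries no donor or acceptor, and on such a change in this assay a modest loss, or none beyond the scatter, seems the most likely outcome rather than a gain, given that compound 1 already stands lowest at 280 nM. The expected outcome is a step of a 2.0-fold higher number from compound 1 to compound 4 (0.29 log units; within the scatter). Compound 4 is therefore estimated at 550 nM, with a range from 200 nM to 1600 nM.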

Compound 4, half-maximal inhibitory concentration: 390 nM
For compound 4 the middle estimate is 1.4-fold (0.15 log units) above the measured one; the measured number falls inside the stated range.
By their numbers in this assay, from the lowest: compounds 1 and 4 (each within the scatter of the next); then compound 2; then compound 3.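

Among the compounds shown here, measured in this assay the exchange of hydrogen in place of chloro on an aromatic carbon amounts to a 1.4-fold higher number from compound 1 to compound 4 (0.14 log units; within the scatter) and so gives the first reading at this position of the shared core. The earlier compounds shown here varied only the group on the thiocarbonyl carbon, where every step lies beyond the scatter, whereas this step lies within it, so with piperidin-1-yl in place the chloro is not needed for a number in this range. No measurement given here accounts for this result.

On these data alone, what stays open is whether a larger group at this position, such as methoxy, a phenyl ring or an amine, would also stay within the scatter. As far as these compounds go, it is also open whether the same exchange would read alike with morpholin-4-yl or diisopropylamino on the thiocarbonyl carbon.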